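This account rests on a few compounds, and the source may have more. Where it says the series, first, only, none or still open, it means among the compounds named here.

Measured so far:
- compound 1 `O=C(CCc1cn(C(=O)c2ccccc2)c2ccccc12)N1CCOCC1`: 23.4%
- compound 2 `O=C(CCc1cn(C(=O)c2ccc(Cl)cc2)c2ccccc12)N1CCOCC1`: 26%
- compound 3 `COc1ccc2c(c1)c(CCCC(=O)N1CCOCC1)c(C)n2Cc1ccccc1`: 54.2%

All three were run in an assay on cells for inhibition of Polyunsaturated fatty acid 5-lipoxygenase (Rattus norvegicus), tested at 5 uM; on this read-out lower numbers stand for less inhibition and higher numbers for more inhibition at the one concentration tested (going by the name of the read-out). Compound 3 gives the highest of the three numbers; compound 2 lies nearest to it and compound 1 furthest, and both gaps are beyond the scatter. Among the measured compounds shown here, the only step between compounds differing in one place is a number 2.6 percentage points higher from compound 1 to compound 2 (within the scatter).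

Compound 4 `COc1ccc2c(c1)c(CCCC(=O)N1CCOCC1)c(C)n2C(=O)c1ccc(Cl)cc1` is not yet measured. It differs from compound 3 by (4-chlorophenyl)carbonyl in place of benzyl on an aromatic nitrogen. For the measured compounds named here, no measured step bears on this change directly: the step from compound 1 to compound 2 concerns a chloro in place of hydrogen on an aromatic carbon and says nothing about the group on the aromatic nitrogen. Compounds 1 and 2 do carry a (4-chlorophenyl)carbonyl or phenylcarbonyl on that nitrogen and sit low, but they also differ from compound 3 in other places, so they give only a weak pointer. A drop of modest size is therefore expected, a number 16.2 percentage points lower from compound 3 to compound 4 (beyond the scatter), with wide uncertainty. Compound 4 is estimated at 38%, within 18% to 58%.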

Compound 4, a percentage reported as inhibition, at one concentration (the size of the read-out at that concentration, not a potency): 70.2%
Compound 4: middle estimate off by 32.2 percentage points, on the low side, and the stated range ends below it.
By their numbers in this assay, from the lowest: compounds 1 and 2 (each within the scatter of the next); then compound 3; then compound 4.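

In this assay, replacing benzyl with (4-chlorophenyl)carbonyl on the aromatic nitrogen of this core gives a gain, a number 16 percentage points higher from compound 3 to compound 4 (beyond the scatter), so a carbonyl-linked group at this position is compatible with inhibition at the one concentration tested. Among the compounds shown here, compounds 1 and 2 also carry carbonyl-linked groups on that nitrogen, but they differ from compound 3 in other places, so their low numbers cannot be assigned to that group, and this step is the first one-place reading of the change. No measurement on hand accounts for the gain.

The change introduces the carbonyl and the chloro together, so the compounds shown do not separate their contributions on this core. On these data alone, how a smaller acetyl group on that nitrogen would read remains open.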